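Swapping the Ether Linker of Compound 1 for an Amine

The source may hold more compounds than are shown below. What is called first, only, known or untested is meant among the compounds shown, and "the series" means these compounds.

Compound 1, `CC(C)c1onc(-c2c(Cl)cccc2Cl)c1COc1ccc(COc2ccc(CC(=O)O)cc2)cc1`: 2000 nM
Compound 2, `CC(C)c1onc(-c2ccccc2)c1COc1ccc(CCCC(=O)O)cc1`: 31000 nM
Compound 3, `Cc1cccc(C)c1-c1noc(C(C)C)c1COc1ccc(CCCC(=O)O)cc1`: 7700 nM

In an assay on HEK-293T cells for activation of Bile acid receptor (Homo sapiens), read by a luciferase reporter, with a stated time of 14 h (a lower number here means that less compound is needed, a higher number that more compound is needed for the effect), compound 1 shows the lowest number of the three measured compounds; compound 3 is nearest to it and compound 2 furthest, both gaps lying beyond the usual scatter. Compound 4, `CC(C)c1onc(-c2c(Cl)cccc2Cl)c1COc1ccc(CNc2ccc(CC(=O)O)cc2)cc1`, has not yet been measured. It differs from compound 1 in one place: (4-(carboxymethyl)phenyl)amino in place of 4-(carboxymethyl)phenoxy on a saturated chain carbon bound to an aromatic carbon. Among the measured compounds shown here, the only measured step, a 4.0-fold lower number from compound 2 to compound 3 (0.60 log units; beyond the scatter), concerns a different part of the shared core and gives no guidance on exchanging the linking oxygen for a nitrogen bearing a hydrogen. With nothing measured for such an exchange, a small shift at most is expected for compound 4, a 1.3-fold higher number from compound 1 to compound 4 (0.10 log units; within the scatter). Compound 4 is therefore estimated at 2500 nM, within a range from 800 nM to 8000 nM.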

Compound 4, half-maximal effective concentration: 1600 nM
Estimate against measurement, compound 4: 1.6-fold (0.19 log units) above; the range from low to high includes it.
By their numbers in this assay, from the lowest: compounds 4 and 1 (each within the scatter of the next); then compound 3; then compound 2.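

Putting (4-(carboxymethyl)phenyl)amino in place of 4-(carboxymethyl)phenoxy gives a 1.3-fold lower number from compound 1 to compound 4 (0.10 log units; within the scatter), so the two compounds cannot be told apart. The earlier step showed only a change elsewhere on the shared core; this one shows that the linking oxygen can be exchanged for a nitrogen bearing a hydrogen with no change beyond the scatter. Nothing available explains this result.

Still open, going by these compounds, is how a thioether, a methylated amine or an amide would fare in the same place. On these data alone, the effect of a longer chain there also remains unknown.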